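The source may hold more compounds than are shown below. What is called first, only, known or untested is meant among the compounds shown, and "the series" means these compounds.

Measured in an assay for binding affinity to 5-hydroxytryptamine receptor 1F (Homo sapiens), read by radioligand binding; a higher number here means a weaker inhibitor, a lower number a stronger inhibitor: compound 1 `COc1ccccc1C(=O)Nc1ccc2[nH]cc(C3CCN(C)CC3)c2n1` gives 20 nM; compound 2 `CN1CCC(c2c[nH]c3ccc(NC(=O)c4ccc(C#N)cc4)nc23)CC1` gives 7.2 nM; compound 3 `CN1CCC(c2c[nH]c3ccc(NC(=O)c4ccc([N+](=O)[O-])cc4)nc23)CC1` gives 7.7 nM.

Compound 3 holds the second highest number of the three, and a 1.1-fold higher number from compound 2 to compound 3 (0.03 log units; within the scatter), so it sits beside compound 2, while a 2.6-fold lower number from compound 1 to compound 3 (0.41 log units; beyond the scatter). Compound 4 `CCCCC(=O)Nc1ccc2[nH]cc(C3CCN(C)CC3)c2n1` differs from compound 3 by butyl in place of 4-nitrophenyl on a carbonyl carbon. Within the data shown here, none of the measured steps bears directly on this change: the steps of a 2.8-fold lower number from compound 1 to compound 2 (0.44 log units; beyond the scatter) and a 2.6-fold lower number from compound 1 to compound 3 (0.41 log units; beyond the scatter) swap one substituted phenyl for another, and the shared aromatic ring is kept throughout. With the ring gone, a rise in the number is expected for compound 4, but with a wide range: a 3.9-fold higher number from compound 3 to compound 4 (0.59 log units; beyond the scatter) is the estimated step, giving compound 4 an expected 30 nM, between 8 nM and 120 nM.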

Compound 4, inhibition constant: 14 nM
For compound 4 the middle estimate is 2.1-fold (0.33 log units) above the measured one, within the range that was stated.
By their numbers in this assay, from the lowest: compounds 2, 3, 4 and 1 (each within the scatter of the next, the first and the last beyond it).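

In this assay the aromatic ring on the carbonyl carbon proves not to be required among these compounds, since butyl gives a 1.8-fold higher number from compound 3 to compound 4 (0.26 log units; within the scatter) and a 1.9-fold higher number from compound 2 to compound 4 (0.29 log units; within the scatter) and also a 1.4-fold lower number from compound 1 to compound 4 (0.15 log units; within the scatter). The position therefore accepts an open chain with no ring as well as each of the substituted phenyl groups shown. Nothing available here explains this result.

Going by these compounds, it remains open whether a longer chain, a cyclohexyl group, or a chain ending in an amine or a carboxylic acid would stay in the same range.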